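Adding 2-methylphenyl to compound 3: an estimate

The compounds below may be only part of what the source reports. "The series", "measured", "known", "first", "only" and "open" are said of these compounds alone.

- Compound 1 `O=C1C[C@@H]2O[C@@H](Cc3ccccc3)[C@@H](O)[C@@H]2O1`: 30 nM
- Compound 2 `O=C1C[C@H]2O[C@H](Cc3ccccc3)[C@H](OCc3ccccc3)[C@H]2O1`: 9480 nM
- Compound 3 `O=C1C[C@H]2O[C@H](Cc3ccccc3)[C@H](O)[C@H]2O1`: 1030 nM

In a functional assay on Raji cells (Homo sapiens) for antiproliferative activity, read by MTT assay, with a stated time of 72 h (a higher number here means a weaker inhibitor, a lower number a stronger inhibitor), compound 3, at 1030 nM, holds the second highest of the three numbers. The change to compound 4 `Cc1ccccc1[C@H](c1ccccc1)[C@H]1O[C@@H]2CC(=O)O[C@@H]2[C@H]1O` is 2-methylphenyl in place of hydrogen on a saturated chain carbon bound to an aromatic carbon and a saturated ring carbon. Among the compounds with values here, the closest precedent is a 9.2-fold lower number from compound 2 to compound 3 (0.96 log units; beyond the scatter), where hydrogen replaces benzyl on an oxygen on a saturated carbon. That group sits elsewhere, so it is only a loose guide. The other step, a 34-fold higher number from compound 1 to compound 3 (1.54 log units; beyond the scatter), concerns configuration alone the fact that compounds 1 and 3 differ only in the configuration as drawn and does not address the new group. A modest rise in the number is therefore expected in this assay, with wide uncertainty. The expected step is a 2.4-fold higher number from compound 3 to compound 4 (0.39 log units; beyond the scatter). For compound 4 the estimated value is 2500 nM, with an expected range of 300 nM to 12000 nM.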

Compound 4, half-maximal inhibitory concentration: 5670 nM
Beside the measured number, compound 4's estimate is 2.3-fold (0.36 log units) below it, within the range that was stated.
By their numbers in this assay, from the lowest: compound 1; then compound 3; then compounds 4 and 2 (each within the scatter of the next).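

In this assay, placing 2-methylphenyl on the saturated chain carbon bound to an aromatic carbon and a saturated ring carbon gives a 5.5-fold higher number from compound 3 to compound 4 (0.74 log units; beyond the scatter) and leaves a measurable value. Within the data shown here, the earlier steps covered only configuration and benzyl on oxygen, so this is the only reading at this position, and the added aromatic ring weakens compound 3 without removing its activity. Nothing shown explains this rise.

Open, as far as these compounds go, is whether a methyl or an amine at this carbon would behave alike. From the compounds shown here alone, the effect of 2-methylphenyl on the core of compound 1 also remains open.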